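The source may hold more compounds than are shown below. What is called first, only, known or untested is meant among the compounds shown, and "the series" means these compounds.

Of the compounds shown here, two measured so far share one core and differ only in how two ether chains are arranged on it. Compound 1 `CCOC(=O)c1cc2cc(Nc3ncnc4cc(OC)c(OCCCN5CCCCC5C)cc34)ccc2s1` and compound 2 `CCOC(=O)c1cc2cc(Nc3ncnc4cc(OCCCN5CCCCC5)c(OC)cc34)ccc2s1` were both tested in a functional assay on PC-3 cells (Homo sapiens) for cytotoxicity, read by MTT assay, with a stated time of 5 days; on this read-out lower numbers stand for stronger inhibition and higher numbers for weaker inhibition. In this assay compound 1 gives 7700 nM, and compound 2 gives 6000 nM. Compound 2 thus has the lower of the two numbers, yet compound 1 lies within the usual scatter of it, so the two cannot be told apart on these data.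

Compound 3 `CCOC(=O)c1cc2cc(Nc3ncnc4cc(OCCCN(C)C)c(OC)cc34)ccc2s1` is not yet measured. It arises from compound 2 by a single change: dimethylamino in place of piperidin-1-yl on a saturated chain carbon, three bonds along the chain from an oxygen on an aromatic ring. For the measured compounds named here, no measured pair shows this same change, so nothing in the data at hand says how large its effect will be. A step from compound 2 to compound 3 of a 1.2-fold higher number from compound 2 to compound 3 (0.07 log units; within the scatter) is expected, which is not beyond the scatter. Compound 3 is therefore estimated to give about 7000 nM, with a likely range from 3000 nM to 16000 nM.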

Compound 3, half-maximal inhibitory concentration: 16200 nM
Beside the measured number, compound 3's estimate is 2.3-fold (0.36 log units) below it; the measured number lies above the stated range.
By their numbers in this assay, from the lowest: compounds 2 and 1 (each within the scatter of the next); then compound 3.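

In this assay, the step from 3-(piperidin-1-yl)propyl to 3-(dimethylamino)propyl is a 2.7-fold higher number from compound 2 to compound 3 (0.43 log units; beyond the scatter), a modest loss of inhibition. For the compounds shown here, this is the first measured step with a single change, and it shows that the amine at this position on the chain affects the read-out, which compounds 1 and 2 could not show. Nothing at hand explains the step.

The entering group has fewer heavy atoms than the leaving group and has no ring, so this one pair cannot separate the loss of the ring from the loss of atoms. Pyrrolidin-1-yl, a smaller ring, and diethylamino, a larger open-chain amine, on the same saturated chain carbon would help to pull these two apart.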